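Amino-bearing sulfones: adding one methoxy to compound 3

The source may hold more compounds than are shown below. What is called first, only, known or untested is meant among the compounds shown, and "the series" means these compounds.

Measured in a functional assay on K562 cells (Homo sapiens) for cytotoxicity, read by trypan blue exclusion, with a stated time of 96 h; a lower number here means a stronger inhibitor, a higher number a weaker inhibitor:
- compound 1 `COc1ccc(CS(=O)(=O)/C=C/c2ccccc2OC)cc1N`: 7500 nM
- compound 2 `COc1ccc(CS(=O)(=O)/C=C/c2c(OC)cccc2OC)c([N+](=O)[O-])c1`: 50000 nM
- compound 3 `COc1ccc(CS(=O)(=O)/C=C/c2c(OC)cccc2OC)c(N)c1`: 750 nM

Compound 3, at 750 nM, has the lowest of the three numbers. Compound 1, at 7500 nM, and compound 2, at 50000 nM, both lie higher, and both gaps are beyond the scatter.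

The next compound is compound 4 `COc1ccc(CS(=O)(=O)/C=C/c2c(OC)cc(OC)cc2OC)c(N)c1`, not yet measured in this assay. It carries methoxy in place of hydrogen on an aromatic carbon of compound 3: methoxy in place of hydrogen on an aromatic carbon.

Among the measured compounds shown here, no measured step makes this change. For the measured compounds named here, the only single-place step is a 67-fold lower number from compound 2 to compound 3 (1.82 log units; beyond the scatter), a large one, but it is amino in place of nitro and so bears on the new change only by showing that one substitution can move the number a long way. Compound 1 and compound 3 differ in more than one place, so their gap gives no clean size for a methoxy step, although compound 3 at 750 nM does show that this core can reach well below compound 1.

A moderate step to a lower number is therefore expected, with wide uncertainty and no firm support from a direct precedent. The expected change is a 4.4-fold lower number from compound 3 to compound 4 (0.64 log units; beyond the scatter). For compound 4 the estimated value is 170 nM, with an expected range from 30 nM to 800 nM.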

Compound 4, half-maximal inhibitory concentration: 25 nM
Estimate against measurement, compound 4: 6.8-fold (0.83 log units) above, outside the stated range (below it).
By their numbers in this assay, from the lowest: compound 4; then compound 3; then compound 1; then compound 2.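

In this assay, methoxy in place of hydrogen on an aromatic carbon, at the place meta to two methoxy groups and para to a large group, gives a 30-fold lower number from compound 3 to compound 4 (1.48 log units; beyond the scatter) and so brings the series into a range that compound 3 does not reach. Among the compounds shown here, this is the first step to show that a substitution at this place, well away from the amino group, can move the number by a large amount, and it stands alongside a 67-fold lower number from compound 2 to compound 3 (1.82 log units; beyond the scatter) as the second large single-place step. No measurement here speaks to why adding one methoxy has an effect of this size.

The compounds shown leave open whether the step belongs to methoxy itself or would also appear with another group at this place, such as a hydroxy group, ethoxy or a fluorine atom. They also leave open whether the step depends on the amino group of compound 3 or would appear to the same extent with nitro in its place.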